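This account rests on a few compounds, and the source may have more. Where it says the series, first, only, none or still open, it means among the compounds named here.

Measured compounds:
- compound 1, `Cc1ccccc1Oc1ccc(N2CCC[C@H]2CC(=O)O)cc1`, 74 nM
- compound 2, `O=C(O)C[C@@H]1CCCN1c1ccc(Oc2ccccc2)cc1`, 560 nM
- compound 3, `Cc1cccc(Oc2ccc(N3CCC[C@H]3CC(=O)O)cc2)c1`, 260 nM

In a functional assay on cells for agonist activity at Free fatty acid receptor 1 (Homo sapiens), read by FLIPR and calcium flux, with a stated time of 100 s (a higher number here means that more compound is needed for the effect, a lower number that less compound is needed), compound 3 stands second highest of the three numbers. Its nearest neighbour is compound 2, reached by a 2.2-fold lower number from compound 2 to compound 3 (0.33 log units; beyond the scatter); the furthest is compound 1, reached by a 3.5-fold higher number from compound 1 to compound 3 (0.55 log units; beyond the scatter).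

The next compound, compound 4, `COc1ccc(Oc2ccc(N3CCC[C@H]3CC(=O)O)cc2)cc1`, differs from compound 3 by 4-methoxyphenyl in place of 3-methylphenyl on an oxygen on an aromatic ring. The measured steps that bear on it concern only where a methyl sits or whether it is present at all: a 7.6-fold higher number from compound 1 to compound 2 (0.88 log units; beyond the scatter), a 3.5-fold higher number from compound 1 to compound 3 (0.55 log units; beyond the scatter) and a 2.2-fold lower number from compound 2 to compound 3 (0.33 log units; beyond the scatter), all modest. Among the measured compounds shown here, none of the measured compounds carries a 4-methoxyphenyl or any other substituent at that place, so the data give no direct guide to the new group. The pattern among compounds 1, 2 and 3 shows that the position of a small group on the outer ring shifts the number by modest amounts in either direction, so a modest step of uncertain sign is expected, with a wide range. Compound 4 is therefore estimated at 400 nM, within 120 nM to 1300 nM, which means an expected 1.5-fold higher number from compound 3 to compound 4 (0.19 log units; within the scatter).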

Compound 4, half-maximal effective concentration: 520 nM
Compound 4: the middle estimate sits 1.3-fold (0.11 log units) below what was measured, and the stated range covers the measured number.
By their numbers in this assay, from the lowest: compound 1; then compounds 3, 4 and 2 (each within the scatter of the next, the first and the last beyond it).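

In this assay, adding the methoxy group gives no separable change (a 1.1-fold lower number from compound 2 to compound 4 (0.03 log units; within the scatter)), so this group, the only one here that adds an oxygen to the outer ring, cannot be told apart from having no substituent there. 4-Methoxyphenyl in place of 3-methylphenyl also stays within the scatter (a 2.0-fold higher number from compound 3 to compound 4 (0.30 log units; within the scatter)), whereas 4-methoxyphenyl in place of 2-methylphenyl does not (a 7.0-fold higher number from compound 1 to compound 4 (0.85 log units; beyond the scatter)), which leaves 2-methylphenyl as the only outer ring shown that stands apart from the others. Nothing available accounts for these differences.

Open, as far as these compounds go, is whether a chlorine, an ethyl or an amine on the outer ring would come close to compound 1 (74 nM). Also open, from the compounds shown here alone, is what an amide or a tetrazole in place of the carboxylic acid would do in this assay.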